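Swapping Nitro for Bromo: An Expected Step in Antagonism

The compounds below may be only part of what the source reports. "The series", "measured", "known", "first", "only" and "open" are said of these compounds alone.

Compound 1 `Cc1nc(C#Cc2cc(Br)cc(C#N)c2)cs1` in a functional assay on HEK293 cells for antagonist activity at metabotropic glutamate receptor 5 (Rattus norvegicus), read by calcium flux; on this read-out lower numbers stand for stronger inhibition and higher numbers for weaker inhibition: 1.06 nM
Compound 2 `Cc1nc(C#Cc2cc(F)cc([N+](=O)[O-])c2)cs1` in this assay: 0.61 nM

Compound 2 stands at the low end of these two numbers, and compound 1, its nearest neighbour, lies within the usual scatter of it, so no order between them is claimed. Compound 3 `Cc1nc(C#Cc2cc(F)cc(Br)c2)cs1` differs from compound 2 in one place: bromo in place of nitro on an aromatic carbon. Within the data shown here, no step between measured compounds shows this change. Compound 1 already carries a bromo group and gives 1.06 nM in this assay, so little movement is anticipated. The step is estimated at a 2.1-fold higher number from compound 2 to compound 3 (0.33 log units; beyond the scatter), a slight drift toward weaker inhibition that stays within the scatter. Compound 3 is expected to give 1.3 nM, within 0.4 nM to 4.5 nM.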

Compound 3, half-maximal inhibitory concentration: 1.11 nM
The estimate for compound 3 lay 1.2-fold (0.07 log units) above the measured number, and the stated range covers the measured number.
By their numbers in this assay, from the lowest: compounds 2, 1 and 3 (each within the scatter of the next).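

In this assay, bromo in place of nitro on an aromatic carbon, meta to a fluoro group, gives a 1.8-fold higher number from compound 2 to compound 3 (0.26 log units; within the scatter) and so shows that this position accepts either group with no difference that can be told from the scatter. Fluoro in place of cyano on an aromatic carbon, with the bromo group kept, gives a 1.0-fold higher number from compound 1 to compound 3 (0.02 log units; within the scatter) and likewise separates nothing. No available evidence bears on these two steps.

On these data alone, whether an amine, a carboxylic acid or a longer chain at the bromo position would stay within the scatter remains open.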